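A few compounds are considered here, and "the series" means these few. Any claim that something is new, unique, unknown or untested is made for them only; others in the source may bear on it.

Measured compounds:
compound 1, `O=C(NO)c1ccc(NCc2nc(-c3cccc(Cl)c3)nn2-c2ccccc2)cc1`: 61.2%
compound 2, `O=C(NO)c1ccc(NCc2nc(-c3ccsc3)nn2-c2ccccc2)cc1`: 53.4%

In an assay on Sf9 cells for inhibition of protein deacetylase HDAC6 (Homo sapiens), read by fluorescence, with a stated time of 40 min, tested at 100 nM (a higher number here means more inhibition at the concentration tested (going by the name of the read-out), a lower number less inhibition), compound 1 gives 61.2%, and compound 2 gives 53.4%. Within the data shown here, of these two numbers compound 2 has the lower one, but its only neighbour is compound 1, and the single measured step, a number 7.8 percentage points lower from compound 1 to compound 2 (within the scatter), lies within the scatter, so the two compounds cannot be told apart on these data.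

Compound 3, `Cc1ccc(-c2nc(CNc3ccc(C(=O)NO)cc3)n(-c3ccccc3)n2)o1`, follows from compound 2 by one change: 5-methylfuran-2-yl in place of thiophen-3-yl on an aromatic carbon.

Among the measured compounds shown here, the only step that bears on this change is the one from compound 1 to compound 2, where thiophen-3-yl replaced 3-chlorophenyl on the same aromatic carbon and the read-out moved only within the scatter. Exchanging thiophen-3-yl for 5-methylfuran-2-yl is again a swap of one five-membered aromatic ring with one hetero atom for another at that position, so no step beyond the scatter is expected in this assay, in either direction.

Compound 3 is therefore estimated at 52%, with a range from 38% to 66%, which is expected to amount to a number 1.4 percentage points lower from compound 2 to compound 3 (within the scatter).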

Compound 3, a percentage reported as inhibition, at one concentration (the size of the read-out at that concentration, not a potency): 60.7%
The estimate for compound 3 lay 8.7 percentage points below the measured number; the measured number falls inside the stated range.
By their numbers in this assay, from the lowest: compounds 2, 3 and 1 (each within the scatter of the next).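

In this assay, a third group on this aromatic carbon, between two ring nitrogen atoms, again leaves the read-out within the scatter: 5-methylfuran-2-yl in place of thiophen-3-yl gives a number 7.3 percentage points higher from compound 2 to compound 3 (within the scatter), and 5-methylfuran-2-yl in place of 3-chlorophenyl gives a number 0.5 percentage points lower from compound 1 to compound 3 (within the scatter). The position has now carried 3-chlorophenyl and two different five-membered aromatic rings without any step beyond the scatter, even though the change from thiophen-3-yl to 5-methylfuran-2-yl alters the hetero atom, the point of attachment and the methyl group all at once, and these three differences cannot be separated here. No further measurement bears on why these three groups read alike.

What the compounds shown leave open is whether an amine, a carboxylic acid or a longer chain at this position would move the read-out beyond the scatter, since all three groups here are aromatic rings. Also open, on these data alone, is whether the phenyl group elsewhere on the shared core allows changes as freely, and whether compounds alike at this single concentration would also be alike in potency.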